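A few compounds are considered here, and "the series" means these few. Any claim that something is new, unique, unknown or untested is made for them only; others in the source may bear on it.

Measured in a functional assay on MCF7 cells (Homo sapiens) for antiproliferative activity; a lower number here means a stronger inhibitor, a higher number a weaker inhibitor:
- Compound 1 `CC(C)=CCc1cc(C(=O)Nc2cc3ccc(OCC4CCCN(C)C4)c(C)c3oc2=O)ccc1O`: 2640 nM
- Compound 2 `CC(C)=CCc1cc(C(=O)Nc2cc3ccc(OCC4CCCNC4)c(C)c3oc2=O)ccc1O`: 790 nM
- Compound 3 `CC(C)=CCc1cc(C(=O)Nc2cc3ccc(OCC4CCN(C)C4)c(C)c3oc2=O)ccc1O`: 1550 nM

Compound 3 lies within the scatter of both other compounds, which differ from each other beyond it. Compound 4 `CC(C)=CCc1cc(C(=O)Nc2cc3ccc(OCCCN4CCCCC4)c(C)c3oc2=O)ccc1O` differs from compound 3 as follows: 2-(piperidin-1-yl)ethyl in place of 1-methylpyrrolidin-3-yl on a saturated chain carbon bound to an oxygen on an aromatic ring. Thus 3-(piperidin-1-yl)propoxy replaces (1-methylpyrrolidin-3-yl)methoxy. Two measured ring changes bear on this, a 1.7-fold lower number from compound 1 to compound 3 (0.23 log units; within the scatter) and a 2.0-fold higher number from compound 2 to compound 3 (0.29 log units; within the scatter), and both stay within the scatter. The modest 3.3-fold lower number from compound 1 to compound 2 (0.52 log units; beyond the scatter) concerns only the amine nitrogen. Within the data shown here, no measured compound carries the new side chain, so no direction is supported, and no step beyond the scatter is expected. The expected step is a 1.0-fold lower number from compound 3 to compound 4 (0.01 log units; within the scatter). For compound 4 the estimated value is 1500 nM, with an expected range of 550 nM to 4000 nM.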

Compound 4, half-maximal inhibitory concentration: > 50000 nM
Compound 4 gave a limit, no number; the forecaster's own chance of this, stated with the estimate: 5%; middle value at least 33-fold (1.52 log units) from the limit.
By their numbers in this assay, from the lowest: compounds 2, 3 and 1 (each within the scatter of the next, the first and the last beyond it). At a limit, above all of these: compound 4.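

In this assay, compound 4 gave only a limit, not a number: the limit of > 50000 nM in this assay, at which 1 of the 4 values shown sits. Read against that limit, all three steps are large: an at least 32-fold higher number from compound 3 to compound 4 (1.50 log units; beyond the scatter), an at least 63-fold higher number from compound 2 to compound 4 (1.80 log units; beyond the scatter) and an at least 18-fold higher number from compound 1 to compound 4 (1.27 log units; beyond the scatter). The earlier ring and amine nitrogen changes moved the number far less, so replacing the whole side chain with 3-(piperidin-1-yl)propoxy shows that this position can tolerate much less than those compounds suggested.

The compounds shown leave open whether the piperidin-1-yl ring or the propyl chain carries this effect. A 2-(piperidin-1-yl)ethoxy chain or a 3-(dimethylamino)propoxy chain would separate the two.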